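Swapping the aryl group on a thiazole in a fatty acid receptor series

The source may hold more compounds than are shown below. What is called first, only, known or untested is meant among the compounds shown, and "the series" means these compounds.

Of the compounds shown here, three with a shared acid-bearing core have been measured in a functional assay on CHO cells for agonist activity at Free fatty acid receptor 1 (Homo sapiens), read by FLIPR and calcium flux, tested at 100 nM; on this read-out higher numbers stand for a stronger effect at the one concentration tested and lower numbers for a weaker effect. Compound 1 `O=C(O)CC1COc2cc(OCc3ncc(-c4ccccc4)o3)ccc21` gives 2.34% in this assay. Compound 2 `O=C(O)CC1COc2cc(OCc3csc(-c4ccccc4)n3)ccc21` gives 0.15%. Compound 3 `Cc1ccccc1-c1nc(C)c(COc2ccc3c(c2)OCC3CC(=O)O)s1` gives 10.7%, the highest of the three numbers; its gap to compound 1 lies within the usual scatter, so the two cannot be ordered, while its gap to compound 2 lies beyond the scatter, and here compound 3 stands higher.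

Compound 4 `Cc1nc(-c2ccc(Cl)cc2)sc1COc1ccc2c(c1)OCC2CC(=O)O` has not yet been measured. It differs from compound 3 at one place: 4-chlorophenyl in place of 2-methylphenyl on an aromatic carbon. Within the data shown here, no measured pair in this set shows the effect of this or any other single change, so there is no direct guide to its size.

With only the single-concentration value of compound 3 in hand, the step from compound 3 to compound 4 is expected to be small, of the size a number 2.7 percentage points lower from compound 3 to compound 4 (within the scatter), and not beyond the scatter in either direction. Compound 4 is therefore expected to give about 8% in this assay, within a range from 0% to 25%.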

Compound 4, a percentage reported as activity, at one concentration (the size of the read-out at that concentration, not a potency): 53.4%
Estimate against measurement, compound 4: 45.4 percentage points below, and the stated range ends below it.
By their numbers in this assay, from the lowest: compounds 2, 1 and 3 (each within the scatter of the next, the first and the last beyond it); then compound 4.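

Among these compounds, replacing 2-methylphenyl with 4-chlorophenyl provides the first single-place comparison in this set, and in this assay it produces a number 42.7 percentage points higher from compound 3 to compound 4 (beyond the scatter). This shows that the read-out at the one concentration tested depends strongly on the aryl group at this aromatic carbon, next to the ring nitrogen and next to the ring sulfur. The large step comes from an exchange that leaves the counts of heavy atoms, hydrogen-bond donors and hydrogen-bond acceptors unchanged and adds no net charge, and no measurement in hand accounts for it.

Because the substituent and its place on the phenyl ring change together, the compounds shown cannot tell whether the chlorine or the new location matters more, a question that 2-chlorophenyl and 4-methylphenyl would separate. They also leave open how other groups would behave at this aromatic carbon, such as 4-methoxyphenyl or a pyridine ring in place of the phenyl ring.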